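The source may hold more compounds than are shown below. What is called first, only, known or untested is meant among the compounds shown, and "the series" means these compounds.

Compound 1 `CC(O)(COc1cccc(S(F)(F)(F)(F)F)c1)C(=O)Nc1ccc(S(F)(F)(F)(F)F)cc1` and compound 2 `CC(O)(COc1cccc(S(F)(F)(F)(F)F)c1)C(=O)Nc1cccc(S(F)(F)(F)(F)F)c1` are built from the same atoms joined differently; the difference between the two cores is not broken down here. In a functional assay on LNCaP cells (Homo sapiens) for antiproliferative activity, read by propidium iodide staining, with a stated time of 96 h (on this read-out higher numbers stand for weaker inhibition and lower numbers for stronger inhibition), compound 1 gives 12000 nM, and compound 2 gives 10900 nM, two numbers that lie within the usual scatter of each other. Compound 3 `CC(O)(COc1cccc(C(F)(F)F)c1)C(=O)Nc1cccc(S(F)(F)(F)(F)F)c1` carries, on one ring, a group of 4 heavy atoms (1 carbon, 3 fluorine; no ring) in place of a group of 6 heavy atoms (5 fluorine, 1 sulfur; no ring) (a group of 4 heavy atoms (1 carbon, 3 fluorine; no ring) in place of a group of 6 heavy atoms (5 fluorine, 1 sulfur; no ring), on an aromatic carbon). In this assay compound 3 gives 28800 nM, a step of a 2.6-fold higher number from compound 2 to compound 3 (0.42 log units; beyond the scatter).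

Compound 4 `CC(O)(COc1cccc(S(F)(F)(F)(F)F)c1)C(=O)Nc1ccc(C(F)(F)F)cc1` has not yet been measured. It differs from compound 1 by the same kind of change (a group of 4 heavy atoms (1 carbon, 3 fluorine; no ring) in place of a group of 6 heavy atoms (5 fluorine, 1 sulfur; no ring), on an aromatic carbon), although the group in compound 4 sits para to a large group, whereas in compound 3 it sits meta to a large group. Resting on the step from compound 2 to compound 3 of a 2.6-fold higher number from compound 2 to compound 3 (0.42 log units; beyond the scatter), a step of a 2.5-fold higher number from compound 1 to compound 4 (0.40 log units; beyond the scatter) is expected, because compound 1 gives 12000 nM. Compound 4 is therefore estimated at 30000 nM, with a likely range from 15000 nM to 60000 nM.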

Compound 4, half-maximal inhibitory concentration: 12800 nM
For compound 4 the middle estimate is 2.3-fold (0.37 log units) above the measured one; the whole stated range lies above it.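

In this assay, putting trifluoromethyl where the group of 5 fluorine atoms and 1 sulfur atom stood gives a 1.1-fold higher number from compound 1 to compound 4 (0.03 log units; within the scatter), so on this core the swap produces no change that can be told apart from ordinary assay noise. Set beside the earlier swap, the two results do not clearly disagree: the same change on two cores in this assay, a 2.6-fold higher number (0.42 log units; beyond the scatter) from compound 2 to compound 3 and a 1.1-fold higher number (0.03 log units; within the scatter) from compound 1 to compound 4, 2.5-fold (0.39 log units) apart, within the scatter of two such steps. This shows no measurable difference in how the change behaves on the two cores, but it does not show that the change carries over reliably, since each core offers a single pair and the two pairs make the swap on different rings.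

The compounds shown leave open what the same swap would do with both rings otherwise held constant, and whether the outcome would hold across more pairs. They also leave open how a nitrile or a chlorine atom would compare with trifluoromethyl at the same place on the ring.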